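The source may report more compounds than this note shows. Statements on the series, on what has been measured and on what is new or still open speak of the compounds shown alone.

Measured so far:
compound 1, `O=C(O)c1cccc(NC(=O)C(C2CCCCC2)n2c(-c3ccc(Cl)cc3)nc3cc(F)c(F)cc32)c1` — 1300 nM in an assay on isolated protein for displacement of a labelled ligand from Bile acid receptor (Homo sapiens), read by scintillation proximity assay and radioligand binding; on this read-out higher numbers stand for weaker inhibition and lower numbers for stronger inhibition
compound 2, `O=C(O)c1ccc(NC(=O)[C@H](C2CCCCC2)n2c(-c3ccc(Cl)cc3)nc3cc(F)c(F)cc32)c(C(F)(F)F)c1` — 8 nM
compound 3, `O=C(O)CO[C@H]1CC[C@H](NC(=O)[C@H](C2CCCCC2)n2c(-c3ccc(Cl)nc3)nc3cc(F)c(F)cc32)CC1` — 830 nM

Compound 1 stands at the highest of the three numbers. Its nearest neighbour is compound 3, whose number in this assay is only slightly lower, and the two lie within the scatter of each other, so no order between them can be read. Compound 2 is the distant one: in this assay compound 2 gives a number far below that of compound 1, a gap well beyond the scatter; since compound 2 differs from compound 1 in more than one place, nothing is attributed to any single part of it.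

Compound 4, `Cc1nc(NC(=O)C(C2CCCCC2)n2c(-c3ccc(Cl)cc3)nc3cc(F)c(F)cc32)sc1C(=O)O`, is not yet measured. It differs from compound 1 in one place: 5-carboxy-4-methyl-1,3-thiazol-2-yl in place of 3-carboxyphenyl on an amide-type nitrogen. Among the measured compounds shown here, no measured pair carries this change or anything close to it, so the direction of its effect cannot be taken from the data at hand. The working expectation is therefore no step beyond the scatter, with a wide band on either side: the change from compound 1 to compound 4 in this assay is estimated as a 1.3-fold lower number from compound 1 to compound 4 (0.11 log units; within the scatter). On that basis compound 4 is expected to give about 1000 nM in this assay, with a plausible range from 250 nM to 4000 nM.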

Compound 4, half-maximal inhibitory concentration: 90 nM
Estimate against measurement, compound 4: 11-fold (1.05 log units) above; the measured number lies below the stated range.
By their numbers in this assay, from the lowest: compound 2; then compound 4; then compounds 3 and 1 (each within the scatter of the next).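

In this assay, the group on the amide-type nitrogen turns out to be a place where one change alone moves the number well beyond the scatter (a 14-fold lower number from compound 1 to compound 4 (1.16 log units; beyond the scatter)). Among the compounds shown here, this is the first reading of a single place, since compounds 1, 2 and 3 differ from each other in more than one place. Both groups carry a carboxy substituent and 9 heavy atoms, so the step goes with replacing the six-membered carbon ring by a methyl-bearing five-membered ring with 2 hetero atoms, not with losing or gaining the carboxy substituent, and no measurement here offers a reason for it.

The compounds shown leave open how the step divides among the thiazole ring, its methyl and the placing of the carboxy substituent, which a 5-carboxy-1,3-thiazol-2-yl group with hydrogen in place of the methyl would begin to separate. Also open, from the compounds shown here alone, are whether the carboxylic acid on the thiazole is needed, as a tetrazole or a primary amide in its place would show, and whether a trifluoromethyl group on the ring would add to this change.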